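Solubility notes on a phenethyl-for-cyclohexyl change

The source may hold more compounds than are shown below. What is called first, only, known or untested is meant among the compounds shown, and "the series" means these compounds.

Compound 1 `COc1ccccc1Oc1ccc2c(NCCCNCc3ccco3)ccnc2c1`: 14500 nM
Compound 2 `COc1ccc(F)cc1CNCCCNc1ccnc2cc(C3CCCCC3)ccc12`: 4200 nM

Both compounds were run in a physicochemical assay for solubility, with a stated time of 18 h, at pH 7.4; a lower number here means a less soluble compound, a higher number a more soluble compound. Compound 2 gives the lowest of the two solubility numbers, and compound 1 stands higher by a gap beyond the scatter. Compound 3 `COc1ccc(F)cc1CNCCCNc1ccnc2cc(CCc3ccccc3)ccc12` has not yet been measured. It differs from compound 2 in one place: phenethyl in place of cyclohexyl on an aromatic carbon. For the measured compounds named here, no measured pair shows this change, so the step has no precedent. The step from compound 2 to compound 3 is expected to be small, likely within the scatter, a 1.4-fold lower number from compound 2 to compound 3 (0.15 log units; within the scatter), leaning if anything toward a lower number. Compound 3 is estimated at 3000 nM, in the range 1000 nM to 9000 nM.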

Compound 3, solubility: 4200 nM
Beside the measured number, compound 3's estimate is 1.4-fold (0.15 log units) below it, and the stated range covers the measured number.
By their numbers in this assay, from the lowest: compounds 2 and 3 (each within the scatter of the next); then compound 1.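

In this assay, for the compounds shown here, the first direct reading at this aromatic carbon is no change at the digits printed from compound 2 to compound 3 (within the scatter) on replacing cyclohexyl with phenethyl. At this position, then, a non-aromatic ring of carbon only and an aromatic ring on phenethyl, with 8 heavy atoms against 6, give values within the scatter of each other. No supporting measurement bears on this result.

This single pair leaves open whether the same holds for an amine or a carboxylic acid at this position. From the compounds shown here alone, a longer chain ending in the same phenyl ring also remains open.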